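This account rests on a few compounds, and the source may have more. Where it says the series, first, only, none or still open, it means among the compounds named here.

Measured so far in a functional assay on HUVEC cells (Homo sapiens) for inhibition, with a stated time of 4 days; a lower number here means a stronger inhibitor, a higher number a weaker inhibitor:
- Compound 1 `COc1ccc(C(N)=O)cc1/C=C/c1ccc(Cl)cc1`: 87 nM
- Compound 2 `COc1ccc(C(N)=O)cc1/C=C/c1ccc(Br)cc1`: 560 nM
- Compound 3 `COc1ccc(C(N)=O)cc1/C=C/c1ccc(C)cc1`: 1600 nM

Compound 1 has the lowest number of the three, which makes it the strongest inhibitor in this small set, and its steps to both of the others lie beyond the scatter.

Compound 4 `CCOc1ccc(C(N)=O)cc1/C=C/c1ccc(Cl)cc1` keeps the chloro group of compound 1 and changes methoxy to ethoxy: methyl in place of hydrogen on a saturated chain carbon bound to an oxygen on an aromatic ring. This places methyl in place of hydrogen on a saturated chain carbon bound to an oxygen on an aromatic ring.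

Among the measured compounds shown here, no measured step touches that place, so the evidence is only indirect. All three measured steps exchange a group on an aromatic carbon instead: a 6.4-fold higher number from compound 1 to compound 2 (0.81 log units; beyond the scatter), an 18-fold higher number from compound 1 to compound 3 (1.26 log units; beyond the scatter) and a 2.9-fold higher number from compound 2 to compound 3 (0.46 log units; beyond the scatter). They show that in this series the exchange of one small group can move the number well beyond the scatter, and both changes made to compound 1 raised it. A modest rise is therefore the expectation here, though the direction is not secured by any direct measurement.

The expected step is a 2.9-fold higher number from compound 1 to compound 4 (0.46 log units; beyond the scatter). In this assay the estimate for compound 4 is 250 nM, with an expected range from 70 nM to 900 nM.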

Compound 4, half-maximal inhibitory concentration: 190 nM
Compound 4: the middle estimate sits 1.3-fold (0.12 log units) above what was measured, and the stated range covers the measured number.
By their numbers in this assay, from the lowest: compound 1; then compound 4; then compound 2; then compound 3.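

In this assay, changing methoxy to ethoxy while keeping the chloro group gives a 2.2-fold higher number from compound 1 to compound 4 (0.34 log units; beyond the scatter), the only step shown at this end of the molecule. It shows that this place, a saturated chain carbon bound to an oxygen on an aromatic ring, also responds to a small change: one added methyl is enough to move the number beyond the scatter, so the series is sensitive here as well as at the aromatic carbon that carries the chloro group. With chloro held constant, methoxy gives the lower number of the two, but nothing available explains why adding this methyl raises the number.

On these data alone, a single step cannot show a trend, so it remains open whether a longer chain such as propoxy would raise the number further, or how a branched isopropoxy group or a plain hydroxyl group would compare with methoxy. As far as these compounds go, it is also open whether the change from methoxy to ethoxy would have a similar effect with bromo or methyl in place of chloro.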